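Adding Sulfamoyl to Compound 3: An Expected Weaker Inhibitor

The compounds below may be only part of what the source reports. "The series", "measured", "known", "first", "only" and "open" are said of these compounds alone.

Compound 1, `Oc1ccc(O)c(-c2cc(-c3ccc(Cl)cc3)nn2-c2ccccc2)c1`: 16800 nM
Compound 2, `NS(=O)(=O)c1ccc(-n2nc(-c3ccc(Cl)cc3)cc2-c2cc(O)ccc2O)cc1`: 43100 nM
Compound 3, `O=C1C=CC(=O)C(c2cc(-c3ccc(Cl)cc3)nn2-c2ccccc2)=C1`: 69700 nM

In a functional assay on cells (Cancer cell lines, Homo sapiens) for cytotoxicity, read by sulforhodamine B assay, with a stated time of 48 h (a lower number here means a stronger inhibitor of growth, a higher number a weaker inhibitor of growth), compound 3 carries the highest of the three numbers. Compound 2 lies nearest, within the scatter of it, while compound 1 is furthest: a 4.1-fold higher number from compound 1 to compound 3 (0.62 log units; beyond the scatter). Compound 4, `NS(=O)(=O)c1ccc(-n2nc(-c3ccc(Cl)cc3)cc2C2=CC(=O)C=CC2=O)cc1`, differs from compound 3 in one place: sulfamoyl in place of hydrogen on an aromatic carbon. The same change has been measured once, between the other pair: a 2.6-fold higher number from compound 1 to compound 2 (0.41 log units; beyond the scatter). Applied to compound 3, that single step suggests a modest rise of the same order in this assay, so compound 4 is expected to be the weaker inhibitor of growth: a 2.4-fold higher number from compound 3 to compound 4 (0.39 log units; beyond the scatter). The estimate for compound 4 is 170000 nM, with a range from 70000 nM to 400000 nM.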

Compound 4, concentration for total growth inhibition: 37400 nM
For compound 4 the middle estimate is 4.5-fold (0.66 log units) above the measured one; the whole stated range lies above it.
By their numbers in this assay, from the lowest: compound 1; then compounds 4, 2 and 3 (each within the scatter of the next).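

In this assay, sulfamoyl in place of hydrogen gives no clear rise on the core bearing the non-aromatic ring, with a 1.9-fold lower number from compound 3 to compound 4 (0.27 log units; within the scatter), so the size of this change depends on the core: the same change on two cores in this assay, a 2.6-fold higher number (0.41 log units; beyond the scatter) from compound 1 to compound 2 and a 1.9-fold lower number (0.27 log units; within the scatter) from compound 3 to compound 4, 4.8-fold (0.68 log units) apart, beyond the scatter of two such steps

The exchange of the aromatic ring for the non-aromatic ring likewise shows no clear effect once sulfamoyl is present, with a 1.2-fold lower number from compound 2 to compound 4 (0.06 log units; within the scatter), so that change depends on the group at the far end of the molecule: the same change on two cores in this assay, a 4.1-fold higher number (0.62 log units; beyond the scatter) from compound 1 to compound 3 and a 1.2-fold lower number (0.06 log units; within the scatter) from compound 2 to compound 4, 4.8-fold (0.68 log units) apart, beyond the scatter of two such steps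

From the compounds shown here alone, whether another group at this place, such as an amine or a carboxylic acid, would behave like sulfamoyl stays open. The two changes do not add up. These data do not show what lies behind this.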